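Ester of the acid chain: cytotoxicity in Raji cells

A few compounds are considered here, and "the series" means these few. Any claim that something is new, unique, unknown or untested is made for them only; others in the source may bear on it.

Compound 1 `CC(C)COc1cccc(-c2ccc(C(=O)N(Cc3cccc(OCCCCCC(=O)O)c3)C(C)C)cc2)c1` carries the acid chain. In an ADME assay on Raji cells (Homo sapiens) for cytotoxicity, read by CellTiter-Glo and resazurin assay, with a stated time of 72 h (a lower number here means that less compound is needed, a higher number that more compound is needed for the effect), compound 1 gives only a limit, > 26000 nM. Compound 2 `CC(C)N(Cc1cccc(OCCCCCC(=O)O)c1)C(=O)c1ccc(-c2ccc3[nH]ccc3c2)cc1` replaces the 3-(isobutoxy)phenyl with a 1H-indol-5-yl; in this assay compound 2 likewise gives a limit, > 26000 nM. Compound 3 `CC(C)N(Cc1cccc(OCCCCCC(=O)O)c1)C(=O)c1ccc(-c2c[nH]c3ccccc23)cc1` carries a 1H-indol-3-yl instead, and in this assay compound 3 also gives a limit, > 26000 nM. The step that the two limits leave unreadable from compound 1 to compound 2 cannot be sized, nor can a step that the two limits leave unreadable from compound 1 to compound 3 or a step that the two limits leave unreadable from compound 2 to compound 3, because of the limit of > 26000 nM in this assay, at which 3 of the 3 values shown sit. Compound 1 therefore stands nowhere readable: it shares the common limit with both neighbours.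

Compound 4 `CCOC(=O)CCCCCOc1cccc(CN(C(=O)c2ccc(-c3cccc(OCC(C)C)c3)cc2)C(C)C)c1` differs from compound 1 by ethyl in place of hydrogen on an oxygen next to a carbonyl group. For the measured compounds named here, the aryl end of the molecule is unchanged, and no measured step addresses the carboxy end, so nothing among the three measured compounds sizes this change. All measured values sit at the limit, so no direction can be read, and the expectation is that compound 4 also returns a limit. The estimate for compound 4 in this assay is 30000 nM, with a range from 12000 nM to 90000 nM. The expected step that the limit leaves unreadable from compound 1 to compound 4 is stated only as a nominal figure, since the starting point is itself a limit.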

Compound 4, half-maximal effective concentration: > 26000 nM
Compound 4 ended at the assay's limit; the forecaster's own chance of this, stated with the estimate: 75%; the middle value lies beyond the limit too.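

In this assay compound 4 gives only a limit, > 26000 nM. No step can be read between compound 1 and compound 4, as both sit at the same limit: the limit of > 26000 nM in this assay, at which 4 of the 4 values shown sit.

The compounds shown leave open whether carboxy to ethoxycarbonyl, or any change at the aryl end, alters the read-out in this assay.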